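The source may hold more compounds than are shown below. What is called first, only, known or untested is meant among the compounds shown, and "the series" means these compounds.

Measured compounds:
Compound 1 `CCC1(O)CCN(c2nc(C)c3cc(NC(=O)COc4ccc(OC(F)(F)F)cc4)ccc3n2)CC1`: 59 nM
Compound 2 `Cc1nc(N2CCC(C)(O)CC2)nc2ccc(NC(=O)COc3ccc(Cl)cc3)cc12`: 827 nM

In a functional assay on CHO-K1 cells for antagonist activity at melanin-concentrating hormone receptor 1 (Homo sapiens), read by inositol phosphate accumulation (a higher number here means a weaker inhibitor, a lower number a stronger inhibitor), compound 1 gives 59 nM, the lower of the two numbers; compound 2 gives 827 nM, a higher number that lies beyond the usual scatter. Compound 3 `Cc1nc(N2CCN(C(=O)C3CC3)CC2)nc2ccc(NC(=O)COc3ccc(OC(F)(F)F)cc3)cc12` is not yet measured. It differs from compound 1 by 4-(cyclopropylcarbonyl)piperazin-1-yl in place of 4-ethyl-4-hydroxypiperidin-1-yl on an aromatic carbon. Among the measured compounds shown here, no measured pair shows this change, so the direction rests on judgement alone: a modest rise in the number is expected, a 2.7-fold higher number from compound 1 to compound 3 (0.43 log units; beyond the scatter), with wide uncertainty. For compound 3 the estimated value in this assay is 160 nM, expected to fall between 40 nM and 650 nM.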

Compound 3, half-maximal inhibitory concentration: 30 nM
The estimate for compound 3 lay 5.3-fold (0.73 log units) above the measured number; the measured number lies below the stated range.
By their numbers in this assay, from the lowest: compounds 3 and 1 (each within the scatter of the next); then compound 2.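

In this assay, the place between two ring nitrogen atoms accepts a larger group with a different ring, 4-(cyclopropylcarbonyl)piperazin-1-yl in place of 4-ethyl-4-hydroxypiperidin-1-yl, with a 2.0-fold lower number from compound 1 to compound 3 (0.29 log units; within the scatter). In this pair, the hydrogen-bond donor of the leaving group is therefore not needed to keep the number at this level. Nothing on hand explains the outcome. Going by these compounds, it remains open whether the carbonyl matters here, as a plain 4-methylpiperazin-1-yl group would test. Whether a morpholine ring or an acetyl group in place of the cyclopropylcarbonyl would serve equally also stays unresolved.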